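Cytotoxicity notes: aryl swap at the biaryl terminus

A few compounds are considered here, and "the series" means these few. Any claim that something is new, unique, unknown or untested is made for them only; others in the source may bear on it.

Measured so far in an ADME assay on Raji cells (Homo sapiens) for cytotoxicity, read by CellTiter-Glo and resazurin assay, with a stated time of 72 h; a higher number here means that more compound is needed for the effect, a lower number that less compound is needed:
- compound 1 `CC(C)N(Cc1cccc(OCCCCCC(=O)O)c1)C(=O)c1ccc(-c2cccc3ccccc23)cc1` gives > 26000 nM, a limit of the assay.
- compound 2 `CC(C)N(Cc1cccc(OCCCCCC(=O)O)c1)C(=O)c1ccc(-c2cccc([N+](=O)[O-])c2)cc1` gives > 26000 nM, likewise a limit.
- compound 3 `CCOC(=O)CCCCCOc1cccc(CN(C(=O)c2ccc(-c3cccc4ccccc34)cc2)C(C)C)c1` gives > 26000 nM, again a limit.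

Compound 3 therefore stands at the top limit of this assay, and no number is known for it; the same holds for both other compounds, so that all three values sit at the limit of > 26000 nM in this assay, at which 3 of the 3 values shown sit, and none can be placed relative to the others.

The next compound, compound 4 `CCOC(=O)CCCCCOc1cccc(CN(C(=O)c2ccc(-c3ccc4c(c3)OCCO4)cc2)C(C)C)c1`, keeps the ethyl ester and the rest of compound 3 and changes only the terminal aromatic group (2,3-dihydro-1,4-benzodioxin-6-yl in place of naphthalen-1-yl on an aromatic carbon).

Within the data shown here, two measured steps bear on this. The aryl exchange a step that the two limits leave unreadable from compound 1 to compound 2 is the nearest analogue of the present change, and the ester formation a step that the two limits leave unreadable from compound 1 to compound 3 covers the other part of compound 3; both are unreadable because their endpoints sit at the limit of > 26000 nM in this assay, at which 3 of the 3 values shown sit. Among the measured compounds shown here, no measured step has yet produced a number, so no direction can be read for the step to compound 4.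

Compound 4 is expected to give about 30000 nM, with a range from 12000 nM to 80000 nM, most probably reported again as a limit. The step that the limit leaves unreadable from compound 3 to compound 4 that this estimate means is expected to stay within the scatter.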

Compound 4, half-maximal effective concentration: > 24400 nM
Compound 4 gave a limit, no number (the forecaster's own chance of this, stated with the estimate: 80%); the middle value is on the limit's open side.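

Compound 4 gives > 24400 nM, a limit and not a number. Compound 3 is also held only as a limit, so no step can be read between compound 3 and compound 4. The compounds shown leave open at what concentration any of them acts in this assay, and whether the terminal aromatic group or the ethyl ester changes that concentration at all.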